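The source may hold more compounds than are shown below. What is called first, only, known or untested is meant among the compounds shown, and "the series" means these compounds.

Measured in a functional assay on MCF7 cells (Homo sapiens) for inhibition, read by CCK-8 assay, with a stated time of 48 h; on this read-out lower numbers stand for stronger inhibition of growth and higher numbers for weaker inhibition of growth:
- Compound 1 `CN1CCN(c2ccc(Nc3ncc(Cl)c(NCc4ccccc4)n3)nc2)CC1` gives 17300 nM
- Compound 2 `CCc1ccc(Nc2nc(Nc3ccc(N4CCN(C)CC4)cn3)ncc2Cl)cc1` gives 8230 nM
- Compound 3 `CC(C)c1cccc(Nc2nc(Nc3ccc(N4CCN(C)CC4)cn3)ncc2Cl)c1` gives 8640 nM

Compound 3 cannot be told apart from compound 2 in this assay, as the step of a 1.0-fold higher number from compound 2 to compound 3 (0.02 log units; within the scatter) shows. Its distance from compound 1 is also small, at a 2.0-fold lower number from compound 1 to compound 3 (0.30 log units; within the scatter). The next change leads to compound 4 `COc1cccc(Nc2nc(Nc3ccc(N4CCN(C)CC4)cn3)ncc2Cl)c1`, with methoxy in place of isopropyl on an aromatic carbon.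

Going by the values given here, no measured step makes this exact exchange, so the evidence is indirect. The closest guide is the step between the two aryl compounds, where moving from 4-ethylphenyl to 3-isopropylphenyl left the number essentially unchanged: a 1.0-fold higher number from compound 2 to compound 3 (0.02 log units; within the scatter). Among the compounds with values here, the only step beyond the scatter is a 2.1-fold lower number from compound 1 to compound 2 (0.32 log units; beyond the scatter), and it is modest. It replaces benzyl, whereas compound 4 keeps the aryl amino link of compound 3. Three compounds are a thin basis, but they give no reason to expect a large shift in either direction, and no step beyond the scatter is expected.

The expected step is a 1.0-fold higher number from compound 3 to compound 4 (0.02 log units; within the scatter). For compound 4 the estimated value is 9000 nM, with an expected range from 4500 nM to 18000 nM.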

Compound 4, concentration for 50% growth inhibition: 7540 nM
Estimate against measurement, compound 4: 1.2-fold (0.08 log units) above; the range from low to high includes it.
By their numbers in this assay, from the lowest: compounds 4, 2, 3 and 1 (each within the scatter of the next, the first and the last beyond it).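

In this assay, methoxy on this aromatic carbon, meta to a large group, brings in an oxygen and a hydrogen-bond acceptor in place of the all-carbon isopropyl, yet the step stays within the scatter (a 1.1-fold lower number from compound 3 to compound 4 (0.06 log units; within the scatter)). The comparison with the 4-ethylphenyl compound also stays within the scatter (a 1.1-fold lower number from compound 2 to compound 4 (0.04 log units; within the scatter)), so compound 2, compound 3 and compound 4 cannot be told apart, and this oxygen-bearing group joins two purely hydrocarbon substituents at the same level. The step from the benzyl compound is beyond the scatter but modest (a 2.3-fold lower number from compound 1 to compound 4 (0.36 log units; beyond the scatter)), although this separation from benzyl is not uniform across the aryl compounds, as compound 3 goes against it with a step that stays within the scatter (a 2.0-fold lower number from compound 1 to compound 3 (0.30 log units; within the scatter)).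

No measurement on hand offers an explanation for this flat result. The compounds shown leave open whether an amine or a carboxylic acid on this aromatic carbon, or a chain longer than isopropyl, would produce a step beyond the scatter from compound 4.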